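Lengthening the dicarboxy chain: compound 2 to compound 3

The source may hold more compounds than are shown below. What is called first, only, known or untested is meant among the compounds shown, and "the series" means these compounds.

Measured in a toxicity assay on HeLa cells (Homo sapiens) for cytotoxicity, read by CCK-8 assay, with stated times of 16 h and 24 h; on this read-out lower numbers stand for stronger inhibition and higher numbers for weaker inhibition
- compound 1 `COc1ccc(C2=[N+]3C(=Nc4c(-c5ccccc5)c5c(n4[B-]3(F)F)-c3ccc(OCC(=O)O)cc3CC5)C(c3ccccc3)=C2I)cc1` gives 56 nM
- compound 2 `COc1ccc(C2=[N+]3C(=Nc4c(-c5ccccc5)c5c(n4[B-]3(F)F)-c3ccc(OCC(=O)N[C@@H](CC(=O)O)C(=O)O)cc3CC5)C(c3ccccc3)=C2I)cc1` gives 21 nM

Compound 2 stands lowest of the two measured numbers, with 21 nM as its value. Compound 3 `COc1ccc(C2=[N+]3C(=Nc4c(-c5ccccc5)c5c(n4[B-]3(F)F)-c3ccc(OCC(=O)N[C@@H](CCC(=O)O)C(=O)O)cc3CC5)C(c3ccccc3)=C2I)cc1` changes one place of compound 2: carboxymethyl in place of carboxy on a saturated chain carbon, two bonds along the chain from an amide-type nitrogen and a carbonyl carbon. Among the measured compounds shown here, the only measured step that bears on this is a 2.7-fold lower number from compound 1 to compound 2 (0.43 log units; beyond the scatter) (modest), with (1,2-dicarboxyethyl)amino in place of hydroxy on a carbonyl carbon. For the measured compounds named here, no measured step tests the chain length itself. In this assay no shift beyond the scatter is therefore expected, and no direction can be given. The expected step is a 1.2-fold higher number from compound 2 to compound 3 (0.08 log units; within the scatter) on this estimate. For compound 3 the estimated value is 25 nM with 10 nM to 60 nM as the expected range.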

Compound 3, half-maximal inhibitory concentration: 78 nM
Estimate against measurement, compound 3: 3.1-fold (0.49 log units) below; measured number above the stated range.
By their numbers in this assay, from the lowest: compound 2; then compounds 1 and 3 (each within the scatter of the next).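

In this assay this position proves sensitive to chain length: carboxymethyl in place of carboxy on the saturated chain carbon gives a 3.7-fold higher number from compound 2 to compound 3 (0.57 log units; beyond the scatter), a change that the earlier pair could not test. The lower number obtained with (1,2-dicarboxyethyl)amino therefore does not carry over to (1,3-dicarboxypropyl)amino, which in place of hydroxy on the carbonyl carbon gives a 1.4-fold higher number from compound 1 to compound 3 (0.14 log units; within the scatter), so that this longer group does not separate from compound 1. Nothing available accounts for the difference between the two chains.

Open, going by these compounds, is whether a still longer chain ending in a carboxylic acid would push the number further up or leave it unchanged. Also open, on these data alone, is whether an amine in place of the carboxy at the end of this chain would keep the number of compound 3 or move it.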